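The compounds below may be only part of what the source reports. "The series", "measured", "known", "first", "only" and "open" are said of these compounds alone.

Compounds measured so far:
- compound 1 `CN1CCN(C2CCN(c3nccc4[nH]c(-c5ccc(F)c(F)c5)nc34)CC2)CC1`: 5000 nM
- compound 2 `CN1CCN(C2CCN(c3nccc4[nH]c(-c5ccc(F)c(C(F)(F)F)c5)nc34)CC2)CC1`: 4800 nM

In an ADME assay on CHO cells (Cricetulus griseus) for cytotoxicity, read by MTT assay (a lower number here means that less compound is tolerated, a higher number that more compound is tolerated), compound 2 gives 4800 nM, and compound 1 gives 5000 nM. The two values cannot be told apart, so compound 2 stands level with compound 1 and no order can be drawn between them.

Next in the series is compound 3 `CN1CCN(C2CCN(c3nccc4[nH]c(-c5cc(F)cc(F)c5)nc34)CC2)CC1`, which keeps the shared core and the side chain of compound 2. The change is 3,5-difluorophenyl in place of 4-fluoro-3-(trifluoromethyl)phenyl on an aromatic carbon. Within the data shown here, only one measured step bears on it: a 1.0-fold lower number from compound 1 to compound 2 (0.02 log units; within the scatter). That step also concerns a substituent on the same aryl ring, and it stays within the scatter. Among the measured compounds shown here, it is a single step, and no measured compound carries 3,5-difluorophenyl, so the support is thin. Still, nothing measured points to a shift in either direction in this assay. The expected change is a 1.0-fold higher number from compound 2 to compound 3 (0.02 log units; within the scatter), which means no expected step beyond the scatter. For compound 3 the estimated value is 5000 nM, with an expected range from 2500 nM to 10000 nM.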

Compound 3, half-maximal cytotoxic concentration: 30000 nM
Beside the measured number, compound 3's estimate is 6.0-fold (0.78 log units) below it; the measured number lies above the stated range.
By their numbers in this assay, from the lowest: compounds 2 and 1 (each within the scatter of the next); then compound 3.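

Among these compounds, the aryl group on the aromatic carbon between two ring nitrogen atoms is not indifferent in this assay, although the only earlier step, trifluoromethyl in place of fluoro, gave no separable change. Replacing 4-fluoro-3-(trifluoromethyl)phenyl with 3,5-difluorophenyl gives a 6.3-fold higher number from compound 2 to compound 3 (0.80 log units; beyond the scatter), and replacing 3,4-difluorophenyl with the same group gives a 6.0-fold higher number from compound 1 to compound 3 (0.78 log units; beyond the scatter), so the arrangement of the substituents on this phenyl ring changes the number even when fluoro is the only substituent kind involved. No available evidence accounts for this rise in the tolerated concentration.

With 3,5-difluorophenyl carried by compound 3 alone, these compounds cannot show whether the higher number follows that exact substitution pattern or would also appear with an unsubstituted phenyl, a chloro group or a methoxy group on the ring. Going by these compounds, it also remains open whether the same gain would hold if the side chain of compound 3 were exchanged for a simple primary amine or a carboxylic acid.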